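Acetamide Counterpart of an Acetoxy Chain on a Lactone

This account rests on a few compounds, and the source may have more. Where it says the series, first, only, none or still open, it means among the compounds named here.

Compound 1 `CC(C)(C)C(=O)OCC1(CO)C/C(=C\CCCCCCCCCCCO)C(=O)O1` is the point of departure. In a functional assay on CCRF-CEM cells (Homo sapiens) for antiproliferative activity (a lower number here means a stronger inhibitor of growth, a higher number a weaker inhibitor of growth), compound 1 gives 0.65 ug/mL, the lowest of the two numbers available, and its nearest neighbour is compound 3 `CC(=O)OCCCCCCCCCCCCCCC/C=C1\CC(CO)(COC(=O)C(C)(C)C)OC1=O`, which gives 7.55 ug/mL. The step between them, a 12-fold higher number from compound 1 to compound 3 (1.07 log units; beyond the scatter), is a large loss of growth inhibition. Compound 2 `CC(C)(C)C(=O)OCC1(CO)C/C(=C/CCCCCCCCCCCCCCC=O)C(=O)O1` gives > 10 ug/mL, which is a limit of the assay and not a number, (the limit of > 10 ug/mL in this assay, at which 1 of the 3 values shown sits).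

Compound 4 `CC(=O)NCCCCCCCCCCCCCCC/C=C1\CC(CO)(COC(=O)C(C)(C)C)OC1=O` has not yet been measured. Compared with compound 1 the change is 4-acetamidobutyl in place of hydroxy on a saturated chain carbon, ten or more bonds along the chain from a double-bonded chain carbon. Among the compounds with values here, the entering 4-acetamidobutyl is the close counterpart of the 4-acetoxybutyl that enters in compound 3 at the same place, so the one measured step that bears on the question is a 12-fold higher number from compound 1 to compound 3 (1.07 log units; beyond the scatter), a large loss. No measurement shows how an acetamido end compares with an acetoxy end on this chain, so the same size and direction of step is taken as the best guide, and a large loss is expected in this assay. Compound 4 is therefore expected to give 5.5 ug/mL, within a range from 1.8 ug/mL to 15 ug/mL. This estimate corresponds to an expected step of an 8.5-fold higher number from compound 1 to compound 4 (0.93 log units; beyond the scatter).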

Compound 4, concentration for 50% growth inhibition: 1.08 ug/mL
Compound 4: middle estimate off by 5.1-fold (0.71 log units), on the high side; measured number below the stated range.
By their numbers in this assay, from the lowest: compounds 1 and 4 (each within the scatter of the next); then compound 3. At a limit, above all of these: compound 2.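

On a saturated chain carbon, the large extension of the chain does not by itself cost growth inhibition in this assay: 4-acetamidobutyl in place of hydroxy leaves the two compounds within the scatter of each other (a 1.7-fold higher number from compound 1 to compound 4 (0.22 log units; within the scatter)). What the chain carries at its end matters, since acetamido in place of acetoxy, with the rest of the molecule unchanged, recovers a modest part of the earlier loss (a 7.0-fold lower number from compound 3 to compound 4 (0.84 log units; beyond the scatter)). The acetamido and acetoxy ends, which looked like close counterparts on paper, are therefore not interchangeable on this chain, and the loss seen with compound 3 goes with its acetoxy end rather than with the chain alone.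

The compounds shown leave open how a free amine or a carboxylic acid at the end of this chain would compare, and whether a plain hydroxy on the longer chain would stay level with compound 1, which would separate chain length from end group. Nothing in the data gives a reason why the acetamido end differs from the acetoxy end.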